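Linker length in a bis-aryloxy benzofuran amidine series

This account rests on a few compounds, and the source may have more. Where it says the series, first, only, none or still open, it means among the compounds named here.

Measured compounds, cytotoxicity on L6 cells:
compound 1 `CC(C)NC(=N)c1ccc2oc(-c3ccc(OCCCCOc4ccccc4)cc3)cc2c1` — 6900 nM
compound 2 `c1ccc(OCCCCOc2ccc(-c3cc4cc(C5=NCCN5)ccc4o3)cc2)cc1` — 2900 nM

In an ADME assay on L6 cells (Rattus norvegicus) for cytotoxicity, read by resazurin assay, with a stated time of 70 h (on this read-out lower numbers stand for stronger inhibition and higher numbers for weaker inhibition), compound 1 gives 6900 nM, the highest of the two numbers measured; the nearest neighbour is compound 2, which in this assay gives 2900 nM. For the measured compounds named here, the only step measured so far is a 2.4-fold lower number from compound 1 to compound 2 (0.38 log units; beyond the scatter), and it concerns the group on the aromatic carbon of the core, not the chain between the two aromatic oxygens.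

Compound 3 `CC(C)NC(=N)c1ccc2oc(-c3ccc(OCCCCCCOc4ccccc4)cc3)cc2c1` differs from compound 1 elsewhere: 2-phenoxyethyl in place of phenoxy on a saturated chain carbon, four bonds along the chain from an oxygen on an aromatic ring. The chain that joins the two aryl ethers is lengthened while the group on the core is kept as in compound 1. Going by the values given here, no measured step touches this chain, so the step from compound 1 to compound 2 gives no direct guide to its size or direction. With nothing to point either way, the expected step of a 1.3-fold lower number from compound 1 to compound 3 (0.10 log units; within the scatter) in this assay is taken to lie within the usual scatter, with a wide range to cover the lack of a comparable measured step. Compound 3 is therefore estimated at 5500 nM, expected between 2000 nM and 15000 nM.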

Compound 3, half-maximal inhibitory concentration: 800 nM
Compound 3: the middle estimate sits 6.9-fold (0.84 log units) above what was measured, outside the stated range (below it).
By their numbers in this assay, from the lowest: compound 3; then compound 2; then compound 1.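

In this assay, 2-phenoxyethyl in place of phenoxy on a saturated chain carbon, four bonds along the chain from an oxygen on an aromatic ring, gives an 8.6-fold lower number from compound 1 to compound 3 (0.94 log units; beyond the scatter) with the group on the core unchanged. The chain joining the two aryl ethers is therefore a site of real sensitivity in this read-out, and not merely a spacer that can be lengthened without consequence; this step is numerically larger than the change at the aromatic carbon, a 2.4-fold lower number from compound 1 to compound 2 (0.38 log units; beyond the scatter) on the same read-out. For the compounds shown here, on the numbers so far, lengthening this chain moves the series towards stronger inhibition of L6 cells, and no measurement available here bears on the reason for this shift.

On these data alone, with a single chain step, it remains open whether the number keeps falling with a longer chain, levels off or turns back, and whether a shorter chain would move it the opposite way. As far as these compounds go, it is also open whether the same lengthening has a similar effect with the five-membered ring group of compound 2 on the core, or whether an amine or a carboxylic acid placed on the chain would alter the outcome.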